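A few compounds are considered here, and "the series" means these few. Any claim that something is new, unique, unknown or untested is made for them only; others in the source may bear on it.

Compound 1 `O=C(N/N=C/c1ccccc1O)c1cc(-c2ccc(Cl)cc2)nn1Cc1ccc(Cl)nc1` gives 22500 nM in a functional assay on A549 cells (Homo sapiens) for cytotoxicity, read by MTT assay, with a stated time of 48 h; a lower number here means a less soluble compound, a higher number a more soluble compound. Among the measured compounds shown here, compound 2 `COc1ccc(/C=N/NC(=O)c2cc(-c3ccc(Cl)cc3)nn2Cc2ccc(Cl)nc2)cc1` gives 3300 nM in this assay, the lowest of the two numbers so far; the one measured step, a 6.8-fold lower number from compound 1 to compound 2 (0.83 log units; beyond the scatter), concerns the group on the carbon with a double bond to nitrogen. For the measured compounds named here, compound 3 `COc1ccc(/C=N/NC(=O)c2cc(-c3ccc(OC)cc3)nn2Cc2ccc(Cl)nc2)cc1` differs from compound 2 by methoxy in place of chloro on an aromatic carbon, a change no measured step covers. The step of no change at the digits printed from compound 2 to compound 3 (within the scatter) is therefore expected to stay within the scatter. For compound 3 the estimate in this assay is 3300 nM, with a range of 1400 nM to 8000 nM.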

Compound 3, solubility: 17500 nM
Compound 3: the middle estimate sits 5.3-fold (0.72 log units) below what was measured, and the stated range ends below it.
By their numbers in this assay, from the lowest: compound 2; then compounds 3 and 1 (each within the scatter of the next).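

The aromatic carbon para to a large group is not a silent position: in this assay, methoxy in place of chloro gives a 5.3-fold higher number from compound 2 to compound 3 (0.72 log units; beyond the scatter). The first measured step changed the group on the carbon with a double bond to nitrogen, so the number now responds to a change at a second place on the shared core. No measurement on hand accounts for this step.

One pair cannot define a trend at this position. Going by these compounds, an amine or a carboxylic acid here remains open, as does whether the step holds with the 2-hydroxyphenyl group of compound 1.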